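This account rests on a few compounds, and the source may have more. Where it says the series, first, only, none or still open, it means among the compounds named here.

Of the compounds shown here, three have so far been measured in a functional assay for inhibition of sodium/hydrogen exchanger (Oryctolagus cuniculus); on this read-out lower numbers stand for stronger inhibition and higher numbers for weaker inhibition. Compound 1 `CS(=O)(=O)c1cc(C(=O)N=C(N)N)c(F)cc1F` gives 630 nM, compound 2 `Cc1c(C(=O)N=C(N)N)ccc(Cl)c1S(C)(=O)=O` gives 1300 nM, and compound 3 `CCc1cc(C)c(C(=O)N=C(N)N)cc1S(C)(=O)=O` gives 4.8 nM. Compound 3 therefore stands lowest of the three, and its distance to both compound 1 and compound 2 lies beyond the scatter of repeated measurements, so among these three it is the strongest inhibitor.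

Compound 4 `Cc1cc(Sc2cccc(Cl)c2)c(S(C)(=O)=O)cc1C(=O)N=C(N)N` has not yet been measured. It differs from compound 3 in one place: (3-chlorophenyl)sulfanyl in place of ethyl on an aromatic carbon. The ethyl chain is thus exchanged for a far larger group that brings its own aromatic ring and a chlorine atom, sitting ortho to the methylsulfonyl group and para to the group of 6 heavy atoms.

Going by the values given here, no two measured compounds differ in only one place, so no measured step speaks directly to this change; the three values only show that compound 3 sits well apart from the other two. For compound 4 a moderate weakening beyond the scatter is expected, that is a rise in the number, a 3.1-fold higher number from compound 3 to compound 4 (0.49 log units; beyond the scatter). Compound 4 is accordingly estimated at 15 nM in this assay, with a likely range from 3 nM to 80 nM.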

Compound 4, half-maximal inhibitory concentration: 37 nM
Compound 4: middle estimate off by 2.5-fold (0.39 log units), on the low side, within the range that was stated.
By their numbers in this assay, from the lowest: compound 3; then compound 4; then compound 1; then compound 2.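

Going by these compounds alone, this is the first measured change at this position, the aromatic carbon ortho to the methylsulfonyl group: in this assay the exchange of ethyl for (3-chlorophenyl)sulfanyl gives a 7.7-fold higher number from compound 3 to compound 4 (0.89 log units; beyond the scatter) and so weakens inhibition by a modest step. The position therefore takes a group of 8 heavy atoms, with its own aromatic ring and a chlorine atom, and compound 4 at 37 nM still gives a value in the low nanomolar range, so the much larger group costs some inhibition without removing it. No measurement shown gives a reason for the rise in the number.

The compounds shown leave open which part of the new group accounts for the step: the sulfur link, the aromatic ring or the chlorine atom. A plain phenyl group, a phenoxy group with oxygen in place of sulfur, the same sulfanyl group without its chlorine, or an amine such as piperidine on this carbon would help to pull these parts apart.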